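The source may hold more compounds than are shown below. What is called first, only, known or untested is meant among the compounds shown, and "the series" means these compounds.

Measured compounds:
- compound 1, `CN(C(=O)NC(=O)c1ccc(F)c(F)c1)c1nc(C(F)(F)F)c(C(=O)N/N=C/c2ccc(C(F)(F)F)cc2)s1`, 6.07 ug/mL
- compound 2, `CN(C(=O)NC(=O)c1ccc(Cl)cc1Cl)c1nc(C(F)(F)F)c(C(=O)N/N=C/c2cccc(C(F)(F)F)c2)s1`, 10.6 ug/mL
- compound 3, `CNc1nc(C)c(C(=O)N/N=C/c2ccccc2C(F)(F)F)s1`, > 100 ug/mL

In a functional assay on A549 cells (Homo sapiens) for inhibition, read by MTT assay, with a stated time of 72 h (a higher number here means a weaker inhibitor, a lower number a stronger inhibitor), compound 2 gives 10.6 ug/mL. Compound 1 gives 6.07 ug/mL in this assay, and the two numbers sit within the usual scatter of each other, so no order can be read between them. For the measured compounds named here, compound 3 gives only a limit in this assay, > 100 ug/mL, and that value is a limit rather than a number; it is the one value that rests at the limit of > 100 ug/mL in this assay, at which 1 of the 3 values shown sits.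

Compound 4, `CN(C(=O)NC(=O)c1ccc(Cl)cc1Cl)c1nc(C(F)(F)F)c(C(=O)N/N=C/c2ccc(C(F)(F)F)cc2)s1`, has not yet been measured in this assay. It differs from compound 2 in one place: 4-(trifluoromethyl)phenyl in place of 3-(trifluoromethyl)phenyl on a carbon with a double bond to nitrogen. Going by the values given here, no measured pair shows this change on its own. Compound 1, which carries the 4-(trifluoromethyl)phenyl group, gives 6.07 ug/mL, and compound 2 with the 3-(trifluoromethyl)phenyl group gives 10.6 ug/mL, two numbers within the scatter of each other. The step from compound 2 to compound 4 is therefore expected to be small, likely none beyond the scatter, a 1.5-fold lower number from compound 2 to compound 4 (0.18 log units; within the scatter). Compound 4 is estimated to give 7 ug/mL in this assay, between 3 ug/mL and 20 ug/mL.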

Compound 4, half-maximal inhibitory concentration: 9.4 ug/mL
For compound 4 the middle estimate is 1.3-fold (0.13 log units) below the measured one; measured number inside the range.
By their numbers in this assay, from the lowest: compounds 1, 4 and 2 (each within the scatter of the next). At a limit, above all of these: compound 3.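

For the compounds shown here, compound 4 gives the first direct reading of the swap of 3-(trifluoromethyl)phenyl for 4-(trifluoromethyl)phenyl on a carbon with a double bond to nitrogen: in this assay this exchange gives a 1.1-fold lower number from compound 2 to compound 4 (0.05 log units; within the scatter) and so leaves no readable difference. Compound 4 also isolates the other place, where 2,4-dichlorophenyl stands in place of 3,4-difluorophenyl on a carbonyl carbon, and that exchange gives a 1.5-fold higher number from compound 1 to compound 4 (0.19 log units; within the scatter) in the same assay. Compound 1 and compound 2 differ in both places at once, so their pair could not separate the two exchanges, whereas these single steps show that, for these groups on this core, neither exchange can be told from the scatter.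

The compounds shown leave open whether the same holds for groups of another kind at either place, such as a nitrile, a methoxy group, an amine or a carboxylic acid on the phenyl ring in place of trifluoromethyl or the halogens, or a longer chain in place of the methyl on the urea nitrogen. Nothing at hand bears on any cause for these two steps.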